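The compounds below may be only part of what the source reports. "The series", "measured", "known", "first", "only" and "open" are said of these compounds alone.

Measured in a functional assay on MDA-MB-231 cells (Homo sapiens) for inhibition, read by MTT assay, with a stated time of 48 h; a higher number here means a weaker inhibitor, a lower number a stronger inhibitor:
- compound 1 `COc1cc(-c2cc(-c3ccc(Br)cc3)nc(-c3ccccc3)n2)cc(OC)c1OC`: > 25000 nM
- compound 2 `COc1ccc(-c2cc(-c3cc(OC)c(OC)c(OC)c3)nc(-c3ccccc3)n2)c(OC)c1`: 1440 nM
- compound 3 `COc1cc(-c2cc(-c3cccc4ccccc34)nc(-c3ccccc3)n2)cc(OC)c1OC`: 3240 nM

Compound 1 gives no number, only a limit: the limit of > 25000 nM in this assay, at which 1 of the 3 values shown sits. Compound 3, at 3240 nM, holds the higher of the two actual numbers, and the gap to the other is a 2.3-fold higher number from compound 2 to compound 3 (0.35 log units; beyond the scatter).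

Next is compound 4 `COc1cc(-c2cc(-c3cccs3)nc(-c3ccccc3)n2)cc(OC)c1OC`, with thiophen-2-yl in place of naphthalen-1-yl on an aromatic carbon. All three measured steps fall at this same place. Two are wide, an at least 17-fold lower number from compound 1 to compound 2 (1.23 log units; beyond the scatter) and an at least 7.7-fold lower number from compound 1 to compound 3 (0.88 log units; beyond the scatter), and one is narrow, a 2.3-fold higher number from compound 2 to compound 3 (0.35 log units; beyond the scatter). None of them brings in a five-membered aromatic ring, so the direction is weakly supported.

A modest move towards a weaker inhibitor is expected in this assay, with a wide margin, given the spread in an at least 7.7-fold lower number from compound 1 to compound 3 (0.88 log units; beyond the scatter). The expected step is a 1.5-fold higher number from compound 3 to compound 4 (0.19 log units; within the scatter). For compound 4 the estimate is 5000 nM, with an expected range of 1500 nM to 20000 nM.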

Compound 4, half-maximal inhibitory concentration: 5110 nM
Estimate against measurement, compound 4: 1.0-fold (0.01 log units) below; measured number inside the range.
By their numbers in this assay, from the lowest: compound 2; then compounds 3 and 4 (each within the scatter of the next). At a limit, above all of these: compound 1.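

A five-membered aromatic ring with one sulfur is now tolerated at this position as well as the larger naphthalen-1-yl: in this assay the change gives a 1.6-fold higher number from compound 3 to compound 4 (0.20 log units; within the scatter), so the loss of heavy atoms from this group leaves the two compounds unseparated. The 2,4-dimethoxyphenyl group still gives the lowest number, with a 3.5-fold higher number from compound 2 to compound 4 (0.55 log units; beyond the scatter), so its gap now holds against two different groups. The 4-bromophenyl compound also stays apart from thiophen-2-yl, with an at least 4.8-fold lower number from compound 1 to compound 4 (0.68 log units; beyond the scatter), but that step is only a bound, since the figure for compound 1 is a limit: the limit of > 25000 nM in this assay, at which 1 of the 4 values shown sits.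

Open, going by these compounds, is whether a single methoxy group, as in 4-methoxyphenyl, or a plain phenyl would match the 2,4-dimethoxyphenyl group here. Also open, on these data alone, is how an aryl group carrying an amine or a carboxylic acid would behave at this position.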